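Cytotoxicity of diaryl-ether and small-substituent analogues

The compounds below may be only part of what the source reports. "The series", "measured", "known", "first", "only" and "open" are said of these compounds alone.

Measured so far:
compound 1, `COCc1ccc(Nc2nnc(Cc3c(Cl)cccc3Cl)o2)cc1`, 100000 nM;
compound 2, `Fc1cccc(F)c1Cc1cnc(Nc2ccc(CCOc3ccncc3)cc2)o1`, 11000 nM;
compound 3, `Fc1cccc(F)c1Cc1cnc(Nc2ccc(Oc3cccnc3)c(Cl)c2)o1`, 16000 nM.

In an ADME assay on MT2 cells (Homo sapiens) for cytotoxicity, read by MTT assay (on this read-out lower numbers stand for higher toxicity in this test and higher numbers for lower toxicity in this test), compound 3 gives 16000 nM, the second highest of the three numbers. Compound 2 gives 11000 nM, and that gap lies within the scatter, so the two cannot be ordered. Compound 1 gives 100000 nM, a gap beyond the scatter, so compound 1 is clearly the least toxic of the three in this test.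

Compound 4, `OCc1ccc(Nc2ncc(Cc3c(F)cccc3F)o2)cc1Cl`, has not yet been measured. It differs from compound 3 in one place: hydroxymethyl in place of (pyridin-3-yl)oxy on an aromatic carbon.

For the measured compounds named here, no direct pair of measured compounds shows this change, so the size of the step is uncertain. Going by the values given here, the only guide is that compound 1, which also carries a small two-heavy-atom group on that ring, gives 100000 nM, while the two compounds with a larger group at that place give lower numbers. On that basis compound 4 is expected to move upward, toward lower toxicity, by a step of roughly a 2.5-fold higher number from compound 3 to compound 4 (0.40 log units; beyond the scatter). Compound 4 is estimated at 40000 nM, in a range from 15000 nM to 100000 nM.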

Compound 4, half-maximal cytotoxic concentration: 90000 nM
Beside the measured number, compound 4's estimate is 2.3-fold (0.35 log units) below it; the measured number falls inside the stated range.
By their numbers in this assay, from the lowest: compounds 2 and 3 (each within the scatter of the next); then compounds 4 and 1 (each within the scatter of the next).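

Read in this assay the replacement of (pyridin-3-yl)oxy by hydroxymethyl on this aromatic carbon, ortho to a chloro group, gives a 5.6-fold higher number from compound 3 to compound 4 (0.75 log units; beyond the scatter) and is the first step here that alters a single place, which shows that this position alone can shift the read-out beyond the scatter. The change is not a simple one: the group goes from 7 heavy atoms to 2, a six-membered aromatic ring with 1 hetero atom is lost, and 0 hydrogen-bond donors and 2 hydrogen-bond acceptors become 1 donor and 1 acceptor, all in the same step. No measured evidence is available to say which of these differences lies behind the higher number.

The compounds shown leave open whether the ring's loss or the hydroxyl matters more, a question that a methoxy group, a plain methyl group or an amine at this place could begin to separate. They also leave open how a longer chain, such as hydroxyethyl, or a carboxylic acid would read out at this position, and whether the step would hold with the chloro group replaced by hydrogen.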